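The source may report more compounds than this note shows. Statements on the series, on what has been measured and on what is new or still open speak of the compounds shown alone.

Series notes. Compound 1 `CC1=C(C(=O)OCC(C)C)C(c2cccs2)NC(=O)N1`, compound 2 `CCCC(=O)C1=C(C)NC(=O)NC1c1cccs1` and compound 3 `CCN(CC)C(=O)C1=C(C)NC(=O)NC1c1cccs1` share one core and differ only in the group on the carbonyl carbon. In an assay on membranes from CHO cells for displacement of a labelled ligand from adenosine receptor A1 (Homo sapiens), read by scintillation counting, with a stated time of 60 min, tested at 1 uM (on this read-out higher numbers stand for more inhibition at the one concentration tested (going by the name of the read-out) and lower numbers for less inhibition), compound 1 gives 25%, compound 2 gives 2% and compound 3 gives 13%. Compound 2 stands lowest of the three numbers: the step of a number 23 percentage points lower from compound 1 to compound 2 (beyond the scatter) and the step of a number 11 percentage points higher from compound 2 to compound 3 (beyond the scatter) both lie beyond the scatter, as does a number 12 percentage points lower from compound 1 to compound 3 (beyond the scatter). Compound 4 `CC1=C(c2ncc(C)o2)C(c2cccs2)NC(=O)N1` has not yet been measured in this assay; relative to compound 2 the change is 5-methyl-1,3-oxazol-2-yl in place of propylcarbonyl on a double-bonded ring carbon. The measured steps that bear on this are the two that leave compound 2 at the same carbonyl carbon, a number 23 percentage points lower from compound 1 to compound 2 (beyond the scatter) and a number 11 percentage points higher from compound 2 to compound 3 (beyond the scatter): read from compound 2, each replacement of the propyl group moved the number upward, and each by a modest amount. Within the data shown here, neither step removed the carbonyl itself, whereas the present change replaces the whole propylcarbonyl with an aromatic ring, so no measured step matches it closely. A modest rise is nevertheless expected, a number 12 percentage points higher from compound 2 to compound 4 (beyond the scatter), with wide uncertainty. Compound 4 is estimated at 14% in this assay, within a range from 2% to 30%.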

Compound 4, a percentage reported as inhibition, at one concentration (the size of the read-out at that concentration, not a potency): 21%
The estimate for compound 4 lay 7 percentage points below the measured number; measured number inside the range.
By their numbers in this assay, from the lowest: compound 2; then compounds 3, 4 and 1 (each within the scatter of the next, the first and the last beyond it).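

In this assay, among these compounds, 5-methyl-1,3-oxazol-2-yl in place of propylcarbonyl on the double-bonded ring carbon gives a number 19 percentage points higher from compound 2 to compound 4 (beyond the scatter) and is the first change to remove the carbonyl from this position. Inhibition at the one concentration tested therefore does not depend on a carbonyl at this position, since a five-membered aromatic ring with 2 hetero atoms also gives a number clear of compound 2, and compound 4 at 21% lies within the scatter of both compound 1 at 25% and compound 3 at 13%. No measurement at hand explains why this replacement raises the number.

The compounds shown leave open how much of the step belongs to the ring itself and how much to its methyl group, a question that the unsubstituted 1,3-oxazol-2-yl group or a 5-ethyl-1,3-oxazol-2-yl group could address. They also leave open how an ionisable group such as a carboxylic acid or a primary amine would read at this carbon, and all of these numbers remain single-concentration readings rather than potencies.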